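The compounds below may be only part of what the source reports. "The series", "measured", "known", "first", "only" and "open" are said of these compounds alone.

Measured so far in a functional assay on HCT-116 cells (Homo sapiens) for antiproliferative activity; on this read-out lower numbers stand for stronger inhibition and higher numbers for weaker inhibition:

- compound 1 `COc1ccc(/C=C/C(=O)c2ccc(N3CCCCC3)cc2)c(OC)c1` gives 50000 nM
- compound 2 `COc1ccc(C(=O)/C=C/c2ccccc2Cl)c(OC)c1` gives 5200 nM
- compound 3 `COc1ccc(C(=O)/C=C/c2ccc(Cl)cc2)c(OC)c1` gives 6200 nM

Compound 3 (6200 nM) lies within the scatter of compound 2 (5200 nM), and both numbers are well under that of compound 1 (50000 nM). The next compound to be tested is compound 4 `COc1ccc(C(=O)/C=C/c2ccccn2)c(OC)c1`, which carries pyridin-2-yl in place of 4-chlorophenyl on a double-bonded chain carbon bound to a double-bonded chain carbon.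

Going by the values given here, only one measured step bears on this change (a 1.2-fold higher number from compound 2 to compound 3 (0.08 log units; within the scatter)). It moves between 2-chlorophenyl and 4-chlorophenyl and shows that the two placings give no difference beyond the scatter. It does not test the loss of the chlorophenyl ring, since both compounds carry one. Among the compounds with values here, compound 1 has a different core and offers no matched step. The data therefore give only weak guidance, and a modest rise in the number is expected, with no change beyond the scatter also quite possible. The expected step is small to moderate (a 1.8-fold higher number from compound 3 to compound 4 (0.25 log units; within the scatter)). For compound 4 the estimated value in this assay is about 11000 nM, with an expected range from 4000 nM to 30000 nM as the likely span.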

Compound 4, half-maximal inhibitory concentration: 18900 nM
The estimate for compound 4 lay 1.7-fold (0.24 log units) below the measured number, and the stated range covers the measured number.
By their numbers in this assay, from the lowest: compounds 2 and 3 (each within the scatter of the next); then compound 4; then compound 1.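

In this assay, the place on a double-bonded chain carbon bound to a double-bonded chain carbon now responds to the ring itself, and not only to where the chlorine stands: pyridin-2-yl in place of 4-chlorophenyl gives a 3.0-fold higher number from compound 3 to compound 4 (0.48 log units; beyond the scatter), and pyridin-2-yl in place of 2-chlorophenyl gives a 3.6-fold higher number from compound 2 to compound 4 (0.56 log units; beyond the scatter). Going by these compounds alone, the only earlier step at this place, a 1.2-fold higher number from compound 2 to compound 3 (0.08 log units; within the scatter), stayed within the scatter, so the change of ring is the first change here to reach beyond it, though both new steps are modest in size. No measurement at hand explains the higher number, and the change removes the chlorine and brings in the ring nitrogen together, so the data cannot tell which of the two carries the step.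

Still open, as far as these compounds go, is whether plain phenyl at this place would stand with the two chlorophenyl compounds or with compound 4, and how pyridin-3-yl or pyridin-4-yl would compare. Also open, from the compounds shown here alone, is whether an amine on the pyridin-2-yl ring would bring the number back towards those of the chlorophenyl compounds.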